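Hydroxyphenyl hydrazones: halogen pattern versus cell inhibition

The compounds below may be only part of what the source reports. "The series", "measured", "known", "first", "only" and "open" are said of these compounds alone.

Of the compounds shown here, two have been measured in a functional assay on MGC-803 cells (Homo sapiens) for inhibition, read by MTT assay; on this read-out lower numbers stand for stronger inhibition and higher numbers for weaker inhibition. Compound 1 `Cc1c(C(=O)N/N=C\c2cccc(F)c2O)oc2cccc(O)c12` gives 8350 nM, and compound 2 `Cc1c(C(=O)N/N=C\c2cc(Cl)cc(Cl)c2O)oc2cccc(O)c12` gives 4360 nM. The gap between the two lies within the usual scatter, so no order between compound 1 and compound 2 can be read from them; compound 1 is one of two numbers that sit close together. For the measured compounds named here, no step between measured compounds that differ in one place is on hand, so there is no measured step to lean on. Compound 3 `Cc1c(C(=O)N/N=C\c2ccc(Br)cc2O)oc2cccc(O)c12` is the next candidate for this assay. It differs from compound 1 in one place: 4-bromo-2-hydroxyphenyl in place of 3-fluoro-2-hydroxyphenyl on a carbon with a double bond to nitrogen. Going by the values given here, both halogenated hydroxyphenyl compounds measured so far sit in the same band, so the step of a 1.3-fold lower number from compound 1 to compound 3 (0.11 log units; within the scatter) is expected to stay within the scatter, with no direction beyond it. Compound 3 is therefore estimated at 6500 nM, within 2500 nM to 16000 nM.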

Compound 3, half-maximal inhibitory concentration: 5460 nM
Compound 3: middle estimate off by 1.2-fold (0.08 log units), on the high side; low and high end bracket the measured number.
By their numbers in this assay, from the lowest: compounds 2, 3 and 1 (each within the scatter of the next).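

In this assay, for the compounds shown here, 4-bromo-2-hydroxyphenyl in place of 3-fluoro-2-hydroxyphenyl on a carbon with a double bond to nitrogen gives a 1.5-fold lower number from compound 1 to compound 3 (0.18 log units; within the scatter) as the first single-place step, and this step sets no order between the two compounds. The halogen and its place on the hydroxyphenyl ring change together in this step, so it shows that this combined change stays within the scatter but cannot separate the two parts. No evidence on hand explains this result.

From the compounds shown here alone, whether a plain 2-hydroxyphenyl group, or an amine or a methoxy group in place of the halogen, would stay in this band remains open. Also open, going by these compounds, is what happens at this position when the hydroxy group itself is replaced, for instance by a carboxylic acid.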